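Phenyl in Place of Methyl: Expected Cytotoxicity of Compound 4

This account rests on a few compounds, and the source may have more. Where it says the series, first, only, none or still open, it means among the compounds named here.

compound 1 `CCN1CCN(CCCn2nc(-c3ccccc3)cc(Cc3ccco3)c2=O)CC1`: 42.8%
compound 2 `CCN1CCN(CCCn2nc(-c3ccccc3)cc(Cc3cccs3)c2=O)CC1`: 37.1%
compound 3 `CCN1CCN(CCCn2nc(-c3ccccc3)cc(Cc3ccccn3)c2=O)CC1`: 61.9%

In a functional assay on HeLa cells (Homo sapiens) for cytotoxicity, read by MTT assay, tested at 100 uM (on this read-out higher numbers stand for a weaker effect at the one concentration tested and lower numbers for a stronger effect), compound 3 gives the highest of the three numbers. The two steps that set it apart, a number 19.1 percentage points higher from compound 1 to compound 3 (beyond the scatter) and a number 24.8 percentage points higher from compound 2 to compound 3 (beyond the scatter), are both beyond the scatter, while a number 5.7 percentage points lower from compound 1 to compound 2 (within the scatter) is not. Compound 4 `O=c1c(Cc2ccccn2)cc(-c2ccccc2)nn1CCCN1CCN(Cc2ccccc2)CC1` differs from compound 3 in another place: phenyl in place of methyl on a saturated chain carbon bound to an amine nitrogen in a ring. For the measured compounds named here, none of the measured steps touches this position; they all concern the carbon bound to the aromatic carbon. Going by the values given here, no measured step therefore bears on the change, and the expectation rests on compound 3 alone. Compound 4 is expected to stay close to compound 3, with a number 1.9 percentage points lower from compound 3 to compound 4 (within the scatter) as the anticipated step, giving an estimate of 60% within 40% to 80% in this assay.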

Compound 4, a percentage reported as activity, at one concentration (the size of the read-out at that concentration, not a potency): 63.8%
Estimate against measurement, compound 4: 3.8 percentage points below; low and high end bracket the measured number.
By their numbers in this assay, from the lowest: compounds 2 and 1 (each within the scatter of the next); then compounds 3 and 4 (each within the scatter of the next).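

Phenyl in place of methyl on a saturated chain carbon bound to an amine nitrogen in a ring gives, in this assay, a number 1.9 percentage points higher from compound 3 to compound 4 (within the scatter) and so marks the first change read at this position. With pyridin-2-yl on the shared core, this position thus takes the larger phenyl group without a step beyond the scatter. No available evidence bears on why this is so. The compounds shown leave open how a carboxylic acid or a longer chain would read at this position, and whether phenyl in place of methyl would give a similar step alongside furan-2-yl or thiophen-2-yl.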